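Swapping a piperidine amide for an amino-ester tail

The source may report more compounds than this note shows. Statements on the series, on what has been measured and on what is new or still open speak of the compounds shown alone.

Compound 3 `COc1ccc(C[C@H]2COC(=O)[C@@H]2Cc2ccc(OC(=O)CCC(=O)N3CCCCC3)c(OC)c2)cc1OC`, compound 2 `COc1ccc(C[C@H]2COC(=O)[C@@H]2Cc2ccc(OCC(=O)N3CCCCC3)c(OC)c2)cc1OC` and compound 1 `COc1ccc(C[C@H]2COC(=O)[C@@H]2Cc2ccc(OCC(=O)Nc3ccccc3)c(OC)c2)cc1OC` share one core and differ only in the side chain attached through an oxygen on an aromatic ring. In an ADME assay on HeLa cells (Homo sapiens) for cytotoxicity, read by MTT assay (a higher number here means a weaker inhibitor, a lower number a stronger inhibitor), compound 3 gives 128000 nM, the lowest of the two numbers seen. Compound 2 gives 293000 nM, so that a 2.3-fold lower number from compound 2 to compound 3 (0.36 log units; beyond the scatter). For compound 1 the result is a limit of the assay, >= 600000 nM, recorded as the limit of >= 600000 nM in this assay, at which 1 of the 3 values shown sits. Compound 4 `COC(=O)[C@H](CC(C)C)NC(=O)CCC(=O)Oc1ccc(C[C@H]2C(=O)OC[C@@H]2Cc2ccc(OC)c(OC)c2)cc1OC` carries (1-(methoxycarbonyl)-3-methylbutyl)amino in place of piperidin-1-yl on a carbonyl carbon. Going by the values given here, only an at least 2.0-fold lower number from compound 1 to compound 2 (0.31 log units; beyond the scatter) concerns a change at the same carbonyl carbon, and no measured step covers an amino-ester group, so a step of about a 1.3-fold higher number from compound 3 to compound 4 (0.10 log units; within the scatter) is expected, close to the scatter. Compound 4 is therefore estimated at 160000 nM, between 55000 nM and 470000 nM.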

Compound 4, half-maximal inhibitory concentration: 53200 nM
Compound 4: the middle estimate sits 3.0-fold (0.48 log units) above what was measured; the measured number lies below the stated range.
By their numbers in this assay, from the lowest: compound 4; then compound 3; then compound 2. At a limit, above all of these: compound 1.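

Going by these compounds alone, at this carbonyl carbon, (1-(methoxycarbonyl)-3-methylbutyl)amino, which has no ring, in place of piperidin-1-yl gives a 2.4-fold lower number from compound 3 to compound 4 (0.38 log units; beyond the scatter) in this assay and so goes further than the earlier steps did. The piperidine ring is therefore not needed for a lower number at this position, and an open chain carrying an ester can take its place.

From the compounds shown here alone, whether a carboxylic acid in place of the methyl ester would move the number further remains open. No measurement shown here explains why the number falls with this change.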